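The compounds below may be only part of what the source reports. "The series", "measured", "known", "first", "only" and "open" are said of these compounds alone.

Measured so far in a functional assay on MCF7 cells (Homo sapiens) for inhibition, read by sulforhodamine B assay, with a stated time of 24 h; on this read-out lower numbers stand for stronger inhibition and higher numbers for weaker inhibition:
compound 1 `N#Cc1c(-c2ccccc2)cn(-c2ccc(S(=O)(=O)Nc3ccccn3)cc2)c1NC(N)=O` gives 7340 nM
compound 2 `N#Cc1c(-c2ccccc2)cn(-c2ccc(S(=O)(=O)Nc3ccccn3)cc2)c1NC(=O)CCC(=O)O` gives 8320 nM

Going by the values given here, compound 2 stands at the higher of the two numbers, with compound 1 as its only neighbour; the single measured step, a 1.1-fold higher number from compound 1 to compound 2 (0.05 log units; within the scatter), lies within the scatter, so the two compounds are not distinguished by this read-out.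

The next step leads to compound 3 `N#Cc1c(-c2ccccc2)cn(-c2ccc(S(=O)(=O)Nc3ccccn3)cc2)c1N1C(=O)CCC1=O`, which differs from compound 2 in one place: 2,5-dioxopyrrolidin-1-yl in place of ((2-carboxyethyl)carbonyl)amino on an aromatic carbon. Among the compounds with values here, the only step recorded so far, a 1.1-fold higher number from compound 1 to compound 2 (0.05 log units; within the scatter), exchanges the group on the carbonyl carbon and leaves the amide linkage intact; it does not cover a ring closure of the kind seen in compound 3, so it bears on the new change only in showing that this position has tolerated two quite different substituents without a shift beyond the scatter. Within the data shown here, on that basis a step of a 1.0-fold lower number from compound 2 to compound 3 (0.02 log units; within the scatter) is expected for compound 3, that is, none beyond the scatter, with the uncertainty widened because no measured pair addresses the loss of both hydrogen-bond donors. Compound 3 is therefore estimated at 8000 nM, within a range of 3500 nM to 18000 nM.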

Compound 3, half-maximal inhibitory concentration: 9930 nM
Compound 3: the middle estimate sits 1.2-fold (0.09 log units) below what was measured; low and high end bracket the measured number.
By their numbers in this assay, from the lowest: compounds 1, 2 and 3 (each within the scatter of the next).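

In this assay, replacing the open-chain ((2-carboxyethyl)carbonyl)amino with the ring of 2,5-dioxopyrrolidin-1-yl gives a 1.2-fold higher number from compound 2 to compound 3 (0.08 log units; within the scatter), and replacing ureido with the same ring gives a 1.4-fold higher number from compound 1 to compound 3 (0.13 log units; within the scatter). The earlier pair varied only the group on the carbonyl carbon, whereas these steps show that the read-out also fails to separate a five-membered non-aromatic ring from an open chain on this aromatic carbon, even though the entering group has 0 hydrogen-bond donors where the leaving group has 2. No supporting measurement is available to explain this lack of separation.

From the compounds shown here alone, since compound 1, compound 2 and compound 3 all lie within the scatter of one another, it remains open whether any group on this aromatic carbon can move the number beyond the scatter, for example a free amine, a six-membered cyclic imide or a longer chain ending in a carboxylic acid. The phenyl group and the cyano group are common to all three compounds, so the compounds shown say nothing about how changes at those places would read out.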